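Hydrazone aryl variation on the shared core, cytotoxicity notes

The source may hold more compounds than are shown below. What is called first, only, known or untested is meant among the compounds shown, and "the series" means these compounds.

Measured compounds:
compound 1 `CN(C)CCn1cnnc1-c1cc(Oc2ccc(NC(=O)N/N=C/c3ccc(Cl)cc3Cl)cc2F)ccn1`: 390 nM in a functional assay on HT-29 cells (Homo sapiens) for cytotoxicity, read by MTT assay, with a stated time of 72 h; on this read-out lower numbers stand for stronger inhibition and higher numbers for weaker inhibition
compound 2 `CN(C)CCn1cnnc1-c1cc(Oc2ccc(NC(=O)N/N=C/c3c(Cl)cccc3Cl)cc2F)ccn1`: 280 nM
compound 3 `COc1ccc(/C=N/NC(=O)Nc2ccc(Oc3ccnc(-c4nncn4CCN(C)C)c3)c(F)c2)c(OC)c1`: 1780 nM

Compound 3 stands highest of the three numbers in this assay. Both steps leading to it are beyond the scatter, a 4.6-fold higher number from compound 1 to compound 3 (0.66 log units; beyond the scatter) and a 6.4-fold higher number from compound 2 to compound 3 (0.80 log units; beyond the scatter), so compound 3 is the least active of the measured set. Compound 1 and compound 2 lie within the scatter of each other, a 1.4-fold lower number from compound 1 to compound 2 (0.14 log units; within the scatter).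

Compound 4 `CN(C)CCn1cnnc1-c1cc(Oc2ccc(NC(=O)N/N=C/c3ccccc3)cc2F)ccn1` has not been measured. The change from compound 3 is phenyl in place of 2,4-dimethoxyphenyl on a carbon with a double bond to nitrogen. Among the measured compounds shown here, no measured step removes the methoxy groups without putting chlorines in their place; the steps that bear on it are those exchanging the 2,4-dimethoxyphenyl for a dichlorophenyl, a 4.6-fold higher number from compound 1 to compound 3 (0.66 log units; beyond the scatter) and a 6.4-fold higher number from compound 2 to compound 3 (0.80 log units; beyond the scatter), both modest. Since phenyl carries neither the methoxy groups nor the chlorines, a lower number than compound 3 is expected, but likely a smaller step than those. Compound 4 is estimated at 800 nM, range 300 nM to 2200 nM, which means an expected step of a 2.2-fold lower number from compound 3 to compound 4 (0.35 log units; beyond the scatter).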

Compound 4, half-maximal inhibitory concentration: 1120 nM
The estimate for compound 4 lay 1.4-fold (0.15 log units) below the measured number, within the range that was stated.
By their numbers in this assay, from the lowest: compounds 2 and 1 (each within the scatter of the next); then compounds 4 and 3 (each within the scatter of the next).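

With the unsubstituted phenyl as reference, the 2,4-dimethoxyphenyl cannot be told apart from it in this assay (a 1.6-fold lower number from compound 3 to compound 4 (0.20 log units; within the scatter)), so on the carbon with a double bond to nitrogen the methoxy groups show no effect beyond the scatter. Both dichlorophenyl groups, in contrast, stand clearly apart from phenyl (a 4.0-fold higher number from compound 2 to compound 4 (0.60 log units; beyond the scatter); a 2.9-fold higher number from compound 1 to compound 4 (0.46 log units; beyond the scatter)), which places the separation within this set with the chlorine-bearing compounds rather than with the methoxy-bearing one. No measurement at hand gives a cause for these steps.

Open, going by these compounds, is whether a single chlorine on the phenyl would suffice to match compound 1 and compound 2, or whether both chlorines are needed. Also open, on these data alone, is whether a trifluoromethyl or a nitrile in place of chlorine would give similar numbers.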